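Chloro to fluoro on the amide-bearing ring of compound 1

The source may report more compounds than this note shows. Statements on the series, on what has been measured and on what is new or still open speak of the compounds shown alone.

In a physicochemical assay for solubility, at pH 6.5 (a higher number here means a more soluble compound, a lower number a less soluble compound), compound 1 `CCCS(=O)(=O)Nc1ccc(Cl)c(C(=O)Nc2cnc3[nH]nc(OC)c3c2)c1F` gives < 1 ug/mL, which is a limit of the assay and not a number (the limit of < 1 ug/mL in this assay, at which 1 of the 3 values shown sits). In this assay compound 2 `CC(C)CS(=O)(=O)Nc1ccc(F)c(C(=O)Nc2cnc3[nH]nc(C4CC4)c3c2)c1Cl` gives 1 ug/mL, and compound 3 `O=C(Nc1cnc2[nH]nc(C3CC3)c2c1)c1c(F)ccc(NS(=O)(=O)CCCF)c1Cl` gives 130 ug/mL. Going by the values given here, the one measured step, a 130-fold higher number from compound 2 to compound 3 (2.11 log units; beyond the scatter), changes the chain on the sulfonyl sulfur and leaves the aromatic ring untouched, so it does not bear on the change considered here. Compound 4 `CCCS(=O)(=O)Nc1ccc(F)c(C(=O)Nc2cnc3[nH]nc(OC)c3c2)c1F` differs from compound 1 by fluoro in place of chloro on an aromatic carbon. Among the compounds with values here, no measured pair covers this exchange, and compound 1 itself gives only a limit. Compound 4 is estimated at 2 ug/mL, within 0.5 ug/mL to 8 ug/mL, the expected step being an at least 2.0-fold higher number from compound 1 to compound 4 (0.30 log units; that floor lies within the scatter), with a real chance that only a limit is reported again.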

Compound 4, solubility: 4 ug/mL
The estimate for compound 4 lay 2.0-fold (0.30 log units) below the measured number; the measured number falls inside the stated range.
By their numbers in this assay, from the lowest: compound 2; then compound 4; then compound 3.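

In this assay, going by these compounds alone, this is the first read step on the aromatic ring, at the carbon para to a (propylsulfonyl)amino group: an at least 4.0-fold higher number from compound 1 to compound 4 (0.60 log units; beyond the scatter), with fluoro in place of chloro. Compound 1 stands at a limit, not a number: the limit of < 1 ug/mL in this assay, at which 1 of the 4 values shown sits. The true size of the step therefore stays unfixed, and only its floor is read, while the earlier step concerned the chain on the sulfonyl sulfur alone.

On these data alone, what an amine or a nitrile at this position would give remains open. Also open, as far as these compounds go, is whether the same exchange carries over to other chains on the sulfonyl sulfur.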